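Fluoro to methyl in a small antiproliferative series

This account rests on a few compounds, and the source may have more. Where it says the series, first, only, none or still open, it means among the compounds named here.

Measured in a functional assay on B16-F10 cells (Mus musculus) for antiproliferative activity, read by MTT assay, with a stated time of 48 h; on this read-out higher numbers stand for weaker inhibition and lower numbers for stronger inhibition:
Compound 1 `COc1ccc(C2OC(c3ccc4ccccc4c3)=NN2C(C)=O)cc1`: 6.86 ug/mL
Compound 2 `CC(=O)N1N=C(c2ccc3ccccc3c2)OC1c1ccc(Br)cc1`: 4.68 ug/mL
Compound 3 `CC(=O)N1N=C(c2ccc3ccccc3c2)OC1c1ccc(F)cc1`: 4.65 ug/mL

These three compounds share one core and differ only in a single group on an aromatic carbon. Compound 3, at 4.65 ug/mL, lies within the scatter of the other two, so its place among them gives no real ranking. Compound 4 `CC(=O)N1N=C(c2ccc3ccccc3c2)OC1c1ccc(C)cc1` has not yet been measured. It carries methyl in place of fluoro on an aromatic carbon, para to a large group: methyl in place of fluoro on an aromatic carbon. Going by the values given here, no measured step involves a methyl group, so the closest guides are the other exchanges of this group: a 1.5-fold lower number from compound 1 to compound 3 (0.17 log units; within the scatter), a 1.5-fold lower number from compound 1 to compound 2 (0.17 log units; within the scatter) and a 1.0-fold lower number from compound 2 to compound 3 (0.00 log units; within the scatter). All three stayed within the scatter, so no step beyond it is expected in this assay. The expected step is a 1.1-fold higher number from compound 3 to compound 4 (0.05 log units; within the scatter). Compound 4 is estimated at 5.2 ug/mL, with an expected range from 3 ug/mL to 8.5 ug/mL.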

Compound 4, half-maximal inhibitory concentration: 3.85 ug/mL
The estimate for compound 4 lay 1.4-fold (0.13 log units) above the measured number, and the stated range covers the measured number.
By their numbers in this assay, from the lowest: compounds 4, 3, 2 and 1 (each within the scatter of the next).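

On this assay the methyl group behaves like the three groups already seen at this place on the ring, with a 1.2-fold lower number from compound 3 to compound 4 (0.08 log units; within the scatter) and a 1.2-fold lower number from compound 2 to compound 4 (0.08 log units; within the scatter) and also a 1.8-fold lower number from compound 1 to compound 4 (0.25 log units; within the scatter) all staying within the scatter. Together with the earlier steps, this means that no two of the four compounds can be told apart, so fluoro, bromo, methoxy and methyl give no ranking here, and a simple carbon group fares no differently from the halogens or the oxygen-linked methoxy. The evidence at hand offers no explanation for why the numbers stay so close.

On these data alone, whether any group at this place can produce a step beyond the scatter remains open, for instance an amine, a carboxylic acid or a longer chain. The compounds shown also say nothing about changes elsewhere on the shared core.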